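The source may report more compounds than this note shows. Statements on the series, on what has been measured and on what is new or still open speak of the compounds shown alone.

Compound 1 `O=C(Nc1cccc(-n2cc(-c3ccncc3)c(-c3ccc(Cl)c(O)c3)n2)c1)Nc1ccc(Cl)c(Cl)c1`: 1030 nM
Compound 2 `COc1cc(-c2nn(-c3cccc(NC(=O)c4ccc(Cl)c(C(F)(F)F)c4)c3)cc2-c2ccncc2)ccc1Cl`: 1770 nM

In a functional assay on CCRF-CEM cells (Homo sapiens) for inhibition, read by sulforhodamine B assay, with a stated time of 48 h (a higher number here means a weaker inhibitor of growth, a lower number a stronger inhibitor of growth), compound 1 gives 1030 nM and compound 2 gives 1770 nM. Compound 2 has the higher of the two numbers, but its gap to compound 1 lies within the scatter, so the two cannot be told apart on these data. Among the measured compounds shown here, no two measured compounds differ in only one place, so no single step has been measured yet.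

Compound 3 `COc1cc(-c2nn(-c3cccc(NC(=O)c4cccc(C(F)(F)F)c4)c3)cc2-c2ccncc2)ccc1Cl` has not been measured. It differs from compound 2 in one place: hydrogen in place of chloro on an aromatic carbon. The chloro that leaves sits ortho to a trifluoromethyl group and para to a large group. For the measured compounds named here, nothing among the measured compounds shows what taking away a chloro does at this spot. A small step in this assay is expected, one within the scatter, a 1.4-fold higher number from compound 2 to compound 3 (0.15 log units; within the scatter), if anything toward a slightly higher number. Compound 3 is estimated at 2500 nM, with a range from 900 nM to 7000 nM.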

Compound 3, concentration for 50% growth inhibition: 1450 nM
The estimate for compound 3 lay 1.7-fold (0.24 log units) above the measured number, within the range that was stated.
By their numbers in this assay, from the lowest: compounds 1, 3 and 2 (each within the scatter of the next).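

In this assay, going from the 4-chloro-3-(trifluoromethyl)phenyl group to the 3-(trifluoromethyl)phenyl group gives a 1.2-fold lower number from compound 2 to compound 3 (0.09 log units; within the scatter). This is the first single change that can be read among these compounds, and it shows that compound 2 and compound 3 cannot be told apart on these data. The chloro, ortho to a trifluoromethyl group and para to a large group, can therefore be replaced by hydrogen with no visible effect on growth inhibition in these cells, and nothing available explains this result.

Still open, from the compounds shown here alone, is whether a different group at this spot, such as an amine or a carboxylic acid, would move the number beyond the scatter. The compounds shown also leave open what the trifluoromethyl group contributes, as no step here replaces it with hydrogen.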